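From Urea to Benzamide: Expected Loss of Cytotoxicity

The source may report more compounds than this note shows. Statements on the series, on what has been measured and on what is new or still open speak of the compounds shown alone.

Compound 1 `O=C(Nc1cccc(-n2cc(-c3ccncc3)c(-c3ccc(Cl)c(O)c3)n2)c1)Nc1cccc(C(F)(F)F)c1`: in a functional assay on OVCAR-3 cells (Homo sapiens) for inhibition, read by sulforhodamine B assay, with a stated time of 48 h (a lower number here means that less compound is tolerated, a higher number that more compound is tolerated), compound 1 gives only a limit, > 32500 nM.
Compound 2 `COc1cc(-c2nn(-c3cccc(NC(=O)Nc4cc(C(F)(F)F)cc(C(F)(F)F)c4)c3)cc2-c2ccncc2)ccc1Cl`: compound 2 gives 3390 nM.
Compound 3 `COc1cc(-c2nn(-c3cccc(NC(=O)Nc4cccc(C(F)(F)F)c4)c3)cc2-c2ccncc2)ccc1Cl`: compound 3 gives 24700 nM.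

Compound 3 holds the highest number among the values shown; the nearest is compound 2, and the step of a 7.3-fold higher number from compound 2 to compound 3 (0.86 log units; beyond the scatter) is the only one beyond the scatter. The step of an at least 1.3-fold lower number from compound 1 to compound 3 (0.11 log units; that floor lies within the scatter) starts from a limit of > 32500 nM in this assay, at which 1 of the 3 values shown sits, and lies within the scatter.

Compound 4 `COc1cc(-c2nn(-c3cccc(NC(=O)c4ccccc4)c3)cc2-c2ccncc2)ccc1Cl` differs from compound 3 by phenyl in place of (3-(trifluoromethyl)phenyl)amino on a carbonyl carbon. For the measured compounds named here, the one step that bears on it, a 7.3-fold higher number from compound 2 to compound 3 (0.86 log units; beyond the scatter), removed a trifluoromethyl and raised the number; the change to compound 4 removes the remaining trifluoromethyl together with the amino, so a further rise in this assay is expected. Compound 4 is therefore estimated at 45000 nM, between 15000 nM and 130000 nM. That estimate means a step of a 1.8-fold higher number from compound 3 to compound 4 (0.26 log units; within the scatter), and the result is expected to come back possibly only as a limit.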

Compound 4, concentration lethal to 50% of the cells: 95800 nM
Estimate against measurement, compound 4: 2.1-fold (0.33 log units) below; the range from low to high includes it.
By their numbers in this assay, from the lowest: compound 2; then compound 3; then compound 4.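

In this assay the change on the carbonyl carbon gives a 3.9-fold higher number from compound 3 to compound 4 (0.59 log units; beyond the scatter) and so moves the number as clearly as the earlier change on the aromatic ring, which gave a 7.3-fold higher number from compound 2 to compound 3 (0.86 log units; beyond the scatter) in the same direction. Across compound 2, compound 3 and compound 4, the number rises as trifluoromethyl groups are lost, and none of the three goes against this order. Nothing measured here gives a cause for the rise.

As far as these compounds go, the amino and the last trifluoromethyl leave together in compound 4, so their shares in the step stay open. A plain phenylamino on the carbonyl carbon would separate them.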